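The compounds below may be only part of what the source reports. "The series", "measured", "known", "first", "only" and "open" are said of these compounds alone.

In a functional assay on HCT-116 cells (Homo sapiens) for inhibition, read by sulforhodamine B assay, with a stated time of 48 h, tested at 50 uM (on this read-out higher numbers stand for more inhibition of growth at the one concentration tested and lower numbers for less inhibition of growth), compound 1 (`COc1ccc(/C=C/C(=O)/C=C/c2ccc(OCc3cn(CCCCOc4cc(=O)oc5ccccc45)nn3)c(OC)c2)cc1OC`) gives 55%, compound 2 (`COc1cccc(/C=C/C(=O)/C=C/c2ccc(OCc3cn(CCCCOc4cc(=O)oc5ccccc45)nn3)c(OC)c2)c1`) gives 44% and compound 3 (`COc1cc(/C=C/C(=O)/C=C/c2ccco2)ccc1OCc1cn(CCCCOc2cc(=O)oc3ccccc23)nn1`) gives 47%. The number for compound 3 stands within the scatter of the other two, as the steps of a number 8 percentage points lower from compound 1 to compound 3 (within the scatter) and a number 3 percentage points higher from compound 2 to compound 3 (within the scatter) show. Compound 4 (`COc1ccccc1/C=C/C(=O)/C=C/c1ccc(OCc2cn(CCCCOc3cc(=O)oc4ccccc34)nn2)c(OC)c1`) differs from compound 3 by 2-methoxyphenyl in place of furan-2-yl on a double-bonded chain carbon bound to a double-bonded chain carbon, with 2-methoxyphenyl in place of furan-2-yl on a double-bonded chain carbon bound to a double-bonded chain carbon. Those two steps exchange furan-2-yl with other aryl groups at this place, and neither exceeds the scatter. The modest step of a number 11 percentage points lower from compound 1 to compound 2 (beyond the scatter) involves a different change. The expected result in this assay is therefore no change at the digits printed from compound 3 to compound 4 (within the scatter), with no shift beyond the scatter. Compound 4 is estimated at 47%, within a range of 35% to 59%.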

Compound 4, percent growth inhibition at one concentration: 43%
Compound 4: middle estimate off by 4 percentage points, on the high side; measured number inside the range.
By their numbers in this assay, from the lowest: compounds 4, 2, 3 and 1 (each within the scatter of the next, the first and the last beyond it).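

In this assay, 2-methoxyphenyl in place of furan-2-yl (a number 4 percentage points lower from compound 3 to compound 4 (within the scatter)) and in place of 3-methoxyphenyl (a number 1 percentage points lower from compound 2 to compound 4 (within the scatter)) stays within the scatter, so these three groups on the double-bonded chain carbon are not told apart. Only 3,4-dimethoxyphenyl separates from 2-methoxyphenyl (a number 12 percentage points lower from compound 1 to compound 4 (beyond the scatter)). Compound 3 goes against a clean split. Its furan-2-yl stays within the scatter of compound 1. No measurement given here accounts for these differences. Going by these compounds, what an amine, a carboxylic acid or a longer chain at this place would give remains open.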